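Trimming a ring from a hydroxamate: expected solubility

The compounds below may be only part of what the source reports. "The series", "measured", "known", "first", "only" and "open" are said of these compounds alone.

Measured so far:
Compound 1 `O=C(NC1(C(=O)NO)CCC1)c1ccc(C#Cc2ccccc2)cc1` gives 5000 nM in a physicochemical assay for solubility; on this read-out higher numbers stand for higher solubility and lower numbers for lower solubility.
Compound 2 `O=C(NC1(C(=O)NO)CCN(Cc2ccccc2)CC1)c1ccc(C#Cc2ccccc2)cc1` gives < 1000 nM in this assay.
Compound 3 `NC(=O)C[C@H](NC(=O)c1ccc(C#Cc2ccccc2)cc1)C(=O)NO` gives 61000 nM in this assay.

All three share the same core, a phenylethynyl-benzamide carrying a hydroxamic acid, and differ only in the group on the amide-type nitrogen. Of the two values that are true numbers, compound 1 stands lowest; compound 3 sits higher by a gap beyond the usual scatter of repeated measurements. The value of compound 2 is a limit of the assay, not a number: it marks (the limit of < 1000 nM in this assay, at which 1 of the 3 values shown sits).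

Compound 4 `CC(NC(=O)c1ccc(C#Cc2ccccc2)cc1)C(=O)NO` has not yet been measured. It differs from compound 1 in one place: 1-(hydroxycarbamoyl)ethyl in place of 1-(hydroxycarbamoyl)cyclobutyl on an amide-type nitrogen. The four-membered ring is gone and a smaller open-chain group takes its place, while the counts of hydrogen-bond donors and acceptors stay the same.

Going by the values given here, no pair of measured compounds shows exactly this kind of change, so the step can only be judged from the three compounds at hand. A modest rise in this assay is expected, within or just beyond the scatter, giving a 2.0-fold higher number from compound 1 to compound 4 (0.30 log units; within the scatter). Compound 4 is therefore estimated at 10000 nM, between 3000 nM and 35000 nM.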

Compound 4, solubility: 29000 nM
Compound 4: middle estimate off by 2.9-fold (0.46 log units), on the low side; the measured number falls inside the stated range.
By their numbers in this assay, from the lowest: compound 1; then compound 4; then compound 3. At a limit, below all of these: compound 2.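

In this assay the exchange of 1-(hydroxycarbamoyl)cyclobutyl for 1-(hydroxycarbamoyl)ethyl on the amide-type nitrogen gives a 5.8-fold higher number from compound 1 to compound 4 (0.76 log units; beyond the scatter) and this is the first step shown that changes one place only, where the earlier compounds could be set side by side only loosely. At this position, then, the read-out responds to an exchange that leaves the counts of hydrogen-bond donors and acceptors as they were, while the four-membered ring goes and the group falls from 8 heavy atoms to 6. Nothing measured here gives a reason for this step, so it stands as an observation for this one pair.

The compounds shown leave open whether the ring or the size of the group counts for more, which a longer open chain or a three-membered carbon ring in the same place could begin to separate. Also open, from the compounds shown here alone, is how the read-out would respond to an amine or a carboxylic acid on this open-chain group.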